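Swapping a ring-nitrogen substituent: from cyclohexylmethyl to cyclohexylcarbonyl

A few compounds are considered here, and "the series" means these few. Any claim that something is new, unique, unknown or untested is made for them only; others in the source may bear on it.

Of the compounds shown here, three have been measured in an assay on CHO cells for displacement of a labelled ligand from Substance-P receptor (Homo sapiens); on this read-out lower numbers stand for stronger inhibition and higher numbers for weaker inhibition. Compound 1 `CN(Cc1cc(C(F)(F)F)cc(C(F)(F)F)c1)C(=O)[C@H]1CN(CC2CCCCC2)C[C@@H]1c1ccccc1` gives 62 nM, the second highest of the three numbers. Compound 2 `CC(C)(C)OC(=O)N1CC[C@H](c2ccccc2)[C@@H](C(=O)NCc2cc(C(F)(F)F)cc(C(F)(F)F)c2)C1` gives 450 nM, a higher number, while compound 3 `CC(=O)N1CCC(C(=O)N2C[C@H](C(=O)N(C)C(C)(C)c3cc(C(F)(F)F)cc(C(F)(F)F)c3)[C@@H](c3ccc(F)cc3C)C2)CC1` gives 0.05 nM, a far lower number; both differ from compound 1 in several places at once. Compound 4 `CN(Cc1cc(C(F)(F)F)cc(C(F)(F)F)c1)C(=O)[C@H]1CN(C(=O)C2CCCCC2)C[C@@H]1c1ccccc1` is the untested neighbour of compound 1: cyclohexylcarbonyl in place of cyclohexylmethyl on an amine nitrogen in a ring. For the measured compounds named here, no measured pair isolates this change, so the direction rests on little. A modest step is expected, a 1.6-fold lower number from compound 1 to compound 4 (0.19 log units; within the scatter), leaning toward a lower number. Compound 4 is therefore estimated at 40 nM, with a plausible range from 8 nM to 200 nM.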

Compound 4, half-maximal inhibitory concentration: 0.68 nM
Compound 4: the middle estimate sits 59-fold (1.77 log units) above what was measured; measured number below the stated range.
By their numbers in this assay, from the lowest: compound 3; then compound 4; then compound 1; then compound 2.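

For the compounds shown here, on this ring nitrogen, the link to the cyclohexyl ring matters far more than the earlier compounds, which differ in several places at once, could reveal. In this assay, cyclohexylcarbonyl in place of cyclohexylmethyl keeps the ring but adds a carbonyl and one hydrogen-bond acceptor, and it gives a 91-fold lower number from compound 1 to compound 4 (1.96 log units; beyond the scatter). Nothing measured here explains why this step is so large.

On these data alone, it remains open whether the carbonyl link alone carries this gain. A cyclohexylsulfonyl or benzoyl group on the same nitrogen would help test how far it extends.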